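The source may report more compounds than this note shows. Statements on the series, on what has been measured and on what is new or still open speak of the compounds shown alone.

Measured compounds:
compound 1 `Cc1nc2ccccc2c(=O)n1/N=C/c1ccc(Oc2ccc(F)cc2)cc1` with 4.21
compound 2 `Cc1ccc(Oc2ccc(/C=N/n3c(C)nc4ccccc4c3=O)cc2)cc1` with 4.32

In a physicochemical assay for lipophilicity, in phosphate buffer, measured as octanol-water partition (on this read-out higher numbers stand for higher lipophilicity and lower numbers for lower lipophilicity), compound 2 gives 4.32, the higher of the two numbers in hand, with compound 1 nearest at 4.21; the step of a number 0.11 log units higher from compound 1 to compound 2 (within the scatter) lies within the scatter, so the two cannot be told apart on this read-out. Compound 3 `Cc1nc2ccccc2c(=O)n1/N=C/c1ccc(Oc2ccc([N+](=O)[O-])cc2)cc1` is the unmeasured member. It differs from compound 2 by nitro in place of methyl on an aromatic carbon, the change sitting on an aromatic carbon of a six-membered aromatic ring of carbon only, para to a large group; read one bond further out, 4-methylphenoxy becomes 4-nitrophenoxy. Within the data shown here, only one measured step exists, a number 0.11 log units higher from compound 1 to compound 2 (within the scatter), and it concerns fluoro against methyl, not nitro against methyl, so no step from this pair bears directly on the change at hand. With nothing in the data to anchor a nitro group, the expectation for compound 3 rests on the change itself, and compound 3 is expected to give 3.55 in this assay, within 3.1 to 4. This corresponds to an expected step of a number 0.77 log units lower from compound 2 to compound 3 (beyond the scatter), downward and beyond the scatter.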

Compound 3, partition coefficient: 4.01
For compound 3 the middle estimate is 0.46 log units below the measured one; the whole stated range lies below it.
By their numbers in this assay, from the lowest: compounds 3, 1 and 2 (each within the scatter of the next, the first and the last beyond it).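

In this assay, nitro in place of methyl on the aromatic carbon gives a number 0.31 log units lower from compound 2 to compound 3 (beyond the scatter), and this is the first step among the compounds shown to lie beyond the scatter, so a change at this place can separate two compounds on this read-out. Nitro in place of fluoro at the same place gives a number 0.20 log units lower from compound 1 to compound 3 (within the scatter), so that pair cannot be told apart, and compound 1 cannot be told apart from compound 2 either: of the three groups at this place, only nitro and methyl are separated, and modestly. No measurement in hand bears on why the step from methyl to nitro has this size.

The compounds shown leave open how an amine, a carboxylic acid or a longer chain such as butyl would read at this same place, and whether any of them would stand beyond the scatter from all three compounds. They also leave open whether nitro in place of methyl would give a step of similar size on another aromatic carbon of the ring or on a different core.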